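The compounds below may be only part of what the source reports. "The series", "measured", "known", "first", "only" and "open" are said of these compounds alone.

Measured so far in an ADME assay on Vero cells (Chlorocebus sabaeus) for cytotoxicity, read by MTT assay, with a stated time of 48 h; on this read-out higher numbers stand for weaker inhibition and lower numbers for stronger inhibition:
- compound 1 `O=C(OC1CCC(CN2CCN(c3cc(=O)c4cc(C(F)(F)F)cc([N+](=O)[O-])c4s3)CC2)CC1)c1ccccc1`: > 64 ug/mL, a limit
- compound 2 `CS(=O)(=O)OC1CCC(CN2CCN(c3cc(=O)c4cc(C(F)(F)F)cc([N+](=O)[O-])c4s3)CC2)CC1`: > 64 ug/mL, a limit
- compound 3 `CS(=O)(=O)NC1CCC(CN2CCN(c3cc(=O)c4cc(C(F)(F)F)cc([N+](=O)[O-])c4s3)CC2)CC1`: 48.5 ug/mL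

Going by the values given here, compound 3 gives the only actual number in the set. Compound 4 `COc1ccccc1C(=O)OC1CCC(CN2CCN(c3cc(=O)c4cc(C(F)(F)F)cc([N+](=O)[O-])c4s3)CC2)CC1` carries ((2-methoxyphenyl)carbonyl)oxy in place of methanesulfonamido on a saturated ring carbon. The closest measured comparison is an at least 1.3-fold lower number from compound 1 to compound 3 (0.12 log units; that floor lies within the scatter), with benzoyloxy leaving. an at least 1.3-fold lower number from compound 2 to compound 3 (0.12 log units; that floor lies within the scatter) is the second relevant step. Both give floors only, and both run towards compound 3, so the change to compound 4 is expected to go the opposite way in this assay, if it shows at all. The expected change is a 1.3-fold higher number from compound 3 to compound 4 (0.12 log units; within the scatter), a higher number that may not exceed the scatter. For compound 4 the estimated value is 64 ug/mL, with an expected range of 35 ug/mL to 100 ug/mL.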

Compound 4, half-maximal inhibitory concentration: > 64 ug/mL
Compound 4: a limit, no number; the forecaster's own chance of this, stated with the estimate: 65%; the middle value sits exactly at the limit.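

In this assay, ((2-methoxyphenyl)carbonyl)oxy in place of methanesulfonamido on the saturated ring carbon gives an at least 1.3-fold higher number from compound 3 to compound 4 (0.12 log units; that floor lies within the scatter). The steps from compound 1 and from compound 2 to compound 4 join two limits and cannot be read, so the added methoxy shows no readable effect. A third group at this ring carbon now ends at the same limit, and methanesulfonamido in compound 3 remains the only one with a number: the limit of > 64 ug/mL in this assay, at which 3 of the 4 values shown sit.

From the compounds shown here alone, how far the values of compound 1, compound 2 and compound 4 lie past that limit stays open. So does the outcome with a free hydroxyl, an amine or a carboxylic acid on this ring carbon.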